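Removing a Fluorine from a Potent Growth Inhibitor

This account rests on a few compounds, and the source may have more. Where it says the series, first, only, none or still open, it means among the compounds named here.

Measured compounds:
- Compound 1, `Cc1cc(-c2nc3ccc(F)cc3s2)ccc1N`: in a functional assay on T47D cells (Breast, Homo sapiens) for inhibition (on this read-out lower numbers stand for stronger inhibition of growth and higher numbers for weaker inhibition of growth), compound 1 gives no result reported.
- Compound 2, `Cc1cc(-c2nc3c(F)cccc3s2)ccc1N`: in this assay compound 2 gives < 10 nM, which is a limit of the assay and not a number.
- Compound 3, `Nc1ccc(-c2nc3ccc(F)cc3s2)cc1I`: in this assay compound 3 gives < 10 nM, again a limit rather than a number.

For the measured compounds named here, compound 2 therefore stands at the edge of what this assay can report: its own value is a limit, the one further value shown is the same limit, and the remaining entry carries no number at all, so the limit of < 10 nM in this assay, at which 2 of the 3 values shown sit, is the only foothold the data offer.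

The next compound, compound 4, `Cc1cc(-c2nc3ccccc3s2)ccc1N`, differs from compound 2 in one place: hydrogen in place of fluoro on an aromatic carbon. Going by the values given here, no measured pair with this change exists here, so its size can only be guessed. Because compound 2 sits at the limit of < 10 nM in this assay, at which 2 of the 3 values shown sit, a step from compound 2 to compound 4 that stays within the scatter, or a modest weakening, is expected: an at least 1.2-fold higher number from compound 2 to compound 4 (0.07 log units; that floor lies within the scatter). Compound 4 is expected to give about 12 nM in this assay, within a range from 3 nM to 50 nM.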

Compound 4, concentration for 50% growth inhibition: 20 nM
Estimate against measurement, compound 4: 1.7-fold (0.22 log units) below; low and high end bracket the measured number.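

For the compounds shown here, compound 4 supplies the first actual number in this small set, which makes the loss of fluoro from this aromatic carbon, ortho to a fused ring and meta to a fused ring, readable for the first time. In this assay, hydrogen in place of fluoro gives an at least 2.0-fold higher number from compound 2 to compound 4 (0.30 log units; that floor lies within the scatter), so the data show no loss of growth inhibition beyond the scatter, although a larger true step remains possible. The value of compound 2, < 10 nM, is a limit and not a number, and only a floor for the step can be read because of where compound 2 sits: the limit of < 10 nM in this assay, at which 2 of the 4 values shown sit.

From the compounds shown here alone, what a chlorine or a methoxy group would do on this same carbon stays open. Compound 1 gives no result reported, so its differently placed fluoro offers no comparison with compound 4.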